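Replacing a Phenolic Hydrogen with Methyl in a Curcumin-like Chain

A few compounds are considered here, and "the series" means these few. Any claim that something is new, unique, unknown or untested is made for them only; others in the source may bear on it.

Compound 1 `COc1cc(/C=C/C(=O)/C=C/C2=C(C)CCCC2(C)C)ccc1O` and compound 2 `COc1ccc(/C=C/C(=O)/C=C/C2=C(C)CCCC2(C)C)cc1O` share one core and differ only in which oxygen carries the methyl. In a functional assay on PC-3 cells (Homo sapiens) for cytotoxicity, read by MTT assay, with a stated time of 72 h (a higher number here means a weaker inhibitor, a lower number a stronger inhibitor), compound 1 gives 21300 nM. In this assay compound 2 gives 37400 nM, the higher of the two numbers, though the gap to compound 1 lies within the scatter. Compound 3 `COc1ccc(/C=C/C(=O)/C=C/C2=C(C)CCCC2(C)C)cc1OC` follows from compound 2 by one change: methyl in place of hydrogen on an oxygen on an aromatic ring. Among the compounds with values here, with no measured step of this kind to lean on, no change beyond the scatter is expected, so the step of a 1.1-fold lower number from compound 2 to compound 3 (0.03 log units; within the scatter) is an estimate of near-equality. Compound 3 is expected to give 35000 nM, within 12000 nM to 100000 nM.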

Compound 3, half-maximal inhibitory concentration: 42000 nM
Beside the measured number, compound 3's estimate is 1.2-fold (0.08 log units) below it, and the stated range covers the measured number.
By their numbers in this assay, from the lowest: compounds 1, 2 and 3 (each within the scatter of the next).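

Hydroxy to methoxy is now a measured step, and on either oxygen it stays within the scatter in this assay: a 1.1-fold higher number from compound 2 to compound 3 (0.05 log units; within the scatter), and a 2.0-fold higher number from compound 1 to compound 3 (0.29 log units; within the scatter). Compound 3 carries no hydroxy on the aromatic ring, so among these compounds a hydroxy there is not needed for a number in this range. Nothing available explains why these numbers stay together.

Still open, going by these compounds, is whether a longer chain on this oxygen, such as ethyl, would move the number beyond the scatter. The same question stands for a group ending in an amine or a carboxylic acid.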